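The source may report more compounds than this note shows. Statements on the series, on what has been measured and on what is new or still open speak of the compounds shown alone.

In an ADME assay on MT4 cells (Homo sapiens) for cytotoxicity (a higher number here means that more compound is tolerated, a lower number that less compound is tolerated), compound 1 `O=C(NC(=S)Nc1cccc(C(F)(F)F)c1)c1ccccc1` reads > 100000 nM, which is a limit of the assay and not a number. Among the measured compounds shown here, compound 2 `FC(F)(F)c1cccc(NC(=S)Nc2ccc(I)cc2)c1` gives 10000 nM, the only true number available, so it serves as the sole anchor. Compound 3 `FC(F)(F)c1cccc(NC(=S)Nc2cccc(Br)c2)c1` has not yet been measured. Its difference from compound 2 is 3-bromophenyl in place of 4-iodophenyl on an amide-type nitrogen. For the measured compounds named here, no measured step offers a guide, so no change beyond the usual scatter is expected, and the estimated move is a 1.2-fold higher number from compound 2 to compound 3 (0.08 log units; within the scatter). For compound 3 the expected value is 12000 nM, with an estimated range from 4000 nM to 40000 nM.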

Compound 3, half-maximal cytotoxic concentration: 9200 nM
Beside the measured number, compound 3's estimate is 1.3-fold (0.12 log units) above it; low and high end bracket the measured number.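

In this assay, putting 3-bromophenyl in place of 4-iodophenyl on the amide-type nitrogen gives a 1.1-fold lower number from compound 2 to compound 3 (0.04 log units; within the scatter). This first readable step shows that these two halogen-bearing rings read alike here, although the halogen and its place on the ring differ together, so neither can be judged alone. Compound 1 offers no step, as its value is a limit and not a number: the limit of > 100000 nM in this assay, at which 1 of the 3 values shown sits.

As far as these compounds go, how a phenyl ring carrying an amine or a carboxylic acid would read at this nitrogen remains open.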